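The source may hold more compounds than are shown below. What is called first, only, known or untested is meant among the compounds shown, and "the series" means these compounds.

Working notes on the series.

All three measured compounds share the core of compound 2 `O=C(O)/C=C/c1ccncc1-c1ccc2ccccc2c1`, and in an assay on a protein complex for inhibition of CDK8/Cyclin C (Homo sapiens), with a stated time of 1 h, tested at 10 uM (on this read-out lower numbers stand for less inhibition and higher numbers for more inhibition at the one concentration tested (going by the name of the read-out)), compound 2 gives 102%, the highest of the three numbers. Compound 1 `CN1CCN(C(=O)/C=C/c2ccncc2-c2ccc3ccccc3c2)CC1` gives 101% in this assay, and compound 3 `O=C(O)CCNC(=O)/C=C/c1ccncc1-c1ccc2ccccc2c1` gives 91%. For the measured compounds named here, the steps among them are a number 1 percentage points higher from compound 1 to compound 2 (within the scatter), a number 10 percentage points lower from compound 1 to compound 3 (within the scatter) and a number 11 percentage points lower from compound 2 to compound 3 (beyond the scatter); each of them exchanges only the group on the carbonyl carbon, and even the one step beyond the scatter is modest.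

Compound 4 `COC(=O)CCc1ccncc1-c1ccc2ccccc2c1` is not yet measured in this assay. Its change from compound 2 is 2-(methoxycarbonyl)ethyl in place of 2-carboxyethenyl on an aromatic carbon. Going by the values given here, this change is of a different kind from the measured steps: it both caps the acid and removes the double bond outside the aromatic rings, and no measured step touches that double bond. The measured steps show that swapping the group on the carbonyl carbon moves this assay little; they give no guide to the saturated chain. The expectation is therefore a step of a number 17 percentage points lower from compound 2 to compound 4 (beyond the scatter), downward but uncertain, with a wide range. Compound 4 is estimated at 85% in this assay, between 55% and 102%.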

Compound 4, a percentage reported as inhibition, at one concentration (the size of the read-out at that concentration, not a potency): 98%
Compound 4: the middle estimate sits 13 percentage points below what was measured; the range from low to high includes it.
By their numbers in this assay, from the lowest: compounds 3, 4, 1 and 2 (each within the scatter of the next, the first and the last beyond it).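

In this assay the change to 2-(methoxycarbonyl)ethyl in place of 2-carboxyethenyl, on an aromatic carbon ortho to a large group and opposite the ring nitrogen, gives a step of a number 4 percentage points lower from compound 2 to compound 4 (within the scatter). The earlier steps shown here exchanged only the group on the carbonyl carbon and all kept the double bond of the chain, whereas this one shows that the number at this position holds when that double bond is gone and the acid is capped as a methyl ester in the same change. For the compounds shown here, the read-out is the size of the inhibition at one concentration and not a potency, so this shows only that the two compounds cannot be told apart at that concentration, not that their potencies match. Nothing available explains why the number holds through this change.

The two parts of the change remain unseparated: a 2-carboxyethyl group would pair the saturated chain with the free carboxylic acid, and a 2-(methoxycarbonyl)ethenyl group would pair the double bond with the methyl ester. Also open, on these data alone, is how far the position reaches, for instance with a longer chain or with an amine at the end of the chain.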